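Moving the Hydroxycarbamoyl Group Around the Phenyl Ring

A few compounds are considered here, and "the series" means these few. Any claim that something is new, unique, unknown or untested is made for them only; others in the source may bear on it.

In a functional assay on MDA-MB-231 cells (Homo sapiens) for cytotoxicity, read by MTT assay, with a stated time of 48 h (a lower number here means a stronger inhibitor, a higher number a weaker inhibitor), compound 1 `COc1cc(/C=C/c2ccc(OCCCCCCC(=O)NO)cc2)cc(OC)c1` gives 780 nM, while compound 2 `COc1cc(/C=C/c2ccc(OCc3cccc(C(=O)NO)c3)cc2)cc(OC)c1` gives 9220 nM, the higher of the two numbers and thus the weaker result. For the measured compounds named here, the single measured step, a 12-fold higher number from compound 1 to compound 2 (1.07 log units; beyond the scatter), puts 3-(hydroxycarbamoyl)phenyl in place of 5-(hydroxycarbamoyl)pentyl on a saturated chain carbon bound to an oxygen on an aromatic ring. Compound 3 `COc1cc(/C=C/c2ccc(OCc3ccc(C(=O)NO)cc3)cc2)cc(OC)c1` has the same atoms as compound 2, joined differently: 4-(hydroxycarbamoyl)phenyl in place of 3-(hydroxycarbamoyl)phenyl on a saturated chain carbon bound to an oxygen on an aromatic ring. The measured step bears on this change only indirectly. It shows that the number can shift widely with the group at this place, but it swaps a chain for a ring and does not test a move on the ring. Only a small change is therefore expected, leaning slightly towards a lower number. The expected step is a 1.7-fold lower number from compound 2 to compound 3 (0.22 log units; within the scatter). For compound 3, the estimated value is 5500 nM, with an expected range of 1800 nM to 15000 nM.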

Compound 3, half-maximal inhibitory concentration: 6880 nM
Beside the measured number, compound 3's estimate is 1.3-fold (0.10 log units) below it, within the range that was stated.
By their numbers in this assay, from the lowest: compound 1; then compounds 3 and 2 (each within the scatter of the next).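

In this assay, the place of the hydroxycarbamoyl group on the ring makes no difference that can be read: a 1.3-fold lower number from compound 2 to compound 3 (0.13 log units; within the scatter) stays within the scatter, so 4-(hydroxycarbamoyl)phenyl and 3-(hydroxycarbamoyl)phenyl cannot be told apart at this position. The chain still stands clear of the ring in its second form, as an 8.8-fold higher number from compound 1 to compound 3 (0.95 log units; beyond the scatter) lies beyond the scatter with 4-(hydroxycarbamoyl)phenyl in place of 5-(hydroxycarbamoyl)pentyl. Across these three compounds, then, the large shift goes with exchanging the chain for a ring, and not with where the group sits on that ring.

Left open is whether a longer chain than 5-(hydroxycarbamoyl)pentyl would give a lower number than compound 1 does. Also open, going by these compounds, is whether a carboxylic acid in place of the hydroxycarbamoyl group would leave the number where it stands. No supporting measurement accounts for either step.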